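Series notes: solubility, cyclohexyl for 4-cyanophenyl

A few compounds are considered here, and "the series" means these few. Any claim that something is new, unique, unknown or untested is made for them only; others in the source may bear on it.

Three compounds carry numbers in a physicochemical assay for solubility, with a stated time of 18 h, at pH 7.4; a higher number here means a more soluble compound, a lower number a less soluble compound. Compound 1 `COc1ccc(Oc2ccc3c(NCCCNCc4ccco4)ccnc3c2)cc1` gives 14500 nM. Compound 2 `COc1ccc(F)cc1CNCCCNc1ccnc2cc(Cc3ccc(C#N)cc3)ccc12` gives 4200 nM, and compound 3 `COc1cccc(CNCCCNc2ccnc3cc(Cc4ccc(C#N)cc4)ccc23)c1O` gives 4200 nM. Compound 2 stands level with compound 3 at the digits shown, the two together the lowest of the three; the gap to compound 1 is the widest in the set and lies beyond the scatter. For the measured compounds named here, the one measured step, no change at the digits printed from compound 2 to compound 3 (within the scatter), changes the group on a saturated chain carbon bound to an amine nitrogen and leaves the read-out unchanged within the scatter.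

Compound 4 `COc1ccc(F)cc1CNCCCNc1ccnc2cc(CC3CCCCC3)ccc12` is not yet measured. It differs from compound 2 as follows: cyclohexyl in place of 4-cyanophenyl on a saturated chain carbon bound to an aromatic carbon. Going by the values given here, no measured step touches this position, so the measured step from compound 2 to compound 3 does not bear on it, and nothing in the set speaks to a cyanophenyl-to-cyclohexyl exchange. The expectation therefore leans on compound 2 at 4200 nM alone, with a wide range. Compound 4 is expected to give 2500 nM, between 700 nM and 8000 nM; the step of a 1.7-fold lower number from compound 2 to compound 4 (0.23 log units; within the scatter) is thus estimated as a modest fall, not clearly beyond the scatter.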

Compound 4, solubility: 4200 nM
The estimate for compound 4 lay 1.7-fold (0.23 log units) below the measured number; measured number inside the range.
By their numbers in this assay, from the lowest: compounds 2, 3 and 4 (each within the scatter of the next); then compound 1.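

In this assay, for the compounds shown here, the first step at the saturated chain carbon bound to an aromatic carbon reads no change at the digits printed from compound 2 to compound 4 (within the scatter). Cyclohexyl in place of 4-cyanophenyl thus removes the nitrile and the aromatic ring without moving the read-out beyond the scatter, although this rests on a single pair. No measurement at hand offers an explanation for this level reading.

Whether the exchange behaves the same way alongside the 2-hydroxy-3-methoxyphenyl group of compound 3 remains open, as the cyclohexyl group is shown only with the 5-fluoro-2-methoxyphenyl group. How the read-out responds to an amine, a carboxylic acid or a longer chain at this position also remains open, as none of these groups appears among the compounds shown.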